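Series notes: pendant 2-fluorophenyl replaced by cyano

The source may report more compounds than this note shows. Statements on the series, on what has been measured and on what is new or still open speak of the compounds shown alone.

Measured so far:
compound 1, `Cc1n[nH]c(C(=O)O)c1Cc1cccc(-c2ccccc2F)c1`, 22%
compound 2, `Cc1n[nH]c(C(=O)O)c1Cc1ccc(-c2ccc(OC(F)(F)F)cc2)cc1`, 29%
compound 3, `Cc1n[nH]c(C(=O)O)c1Cc1ccccc1-c1ccc(F)cc1`, 56%

In an assay on isolated protein for inhibition of 2-Hydroxyacid oxidase 2 (Homo sapiens), tested at 10 uM (a higher number here means a stronger effect of the compound at the concentration tested, a lower number a weaker effect), compound 1 gives 22%, the lowest of the three numbers. Compound 2 gives 29%, which lies within the usual scatter of compound 1. Compound 3 gives 56%, beyond the scatter above compound 1. Going by the values given here, no pair of measured compounds differs in a single place, so no measured step guides the next change.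

Compound 4, `Cc1n[nH]c(C(=O)O)c1Cc1cccc(C#N)c1`, differs from compound 1 by cyano in place of 2-fluorophenyl on an aromatic carbon. The step is expected to be a number 7 percentage points lower from compound 1 to compound 4 (within the scatter), a small fall that stays within the usual scatter. Compound 4 is therefore estimated at 15%, with a range from 0% to 32%.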

Compound 4, a percentage reported as inhibition, at one concentration (the size of the read-out at that concentration, not a potency): 19%
Compound 4: the middle estimate sits 4 percentage points below what was measured, within the range that was stated.
By their numbers in this assay, from the lowest: compounds 4, 1 and 2 (each within the scatter of the next); then compound 3.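

Cyano in place of 2-fluorophenyl gives a number 3 percentage points lower from compound 1 to compound 4 (within the scatter) in this assay, the only single-place step available in the series. On this aromatic carbon, meta to a large group, the six-membered aromatic ring of 2-fluorophenyl can therefore be exchanged for cyano without a shift beyond the scatter. No supporting data bear on the reason for this result.

Going by these compounds, whether a primary amine or a methoxy group on the same carbon would separate from compound 1 remains open. The number for compound 3 also still lacks a single-place comparison.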